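The compounds below may be only part of what the source reports. "The series", "measured", "known", "first", "only" and "open" are said of these compounds alone.

Compound 1 `COc1cc(-c2nnc(SCC(=O)c3ccc(C(F)(F)F)cc3)n2N)cc(OC)c1OC` and compound 2 `COc1cc(-c2nnc(SCC(=O)c3ccc(F)cc3)n2N)cc(OC)c1OC` share one core and differ in a single aromatic substituent. In a functional assay on HCT-116 cells (Homo sapiens) for antiproliferative activity, read by MTT assay, with a stated time of 48 h (on this read-out lower numbers stand for stronger inhibition and higher numbers for weaker inhibition), compound 1 gives 16700 nM, and compound 2 gives 3230 nM, so compound 2 stands as the lower of the two numbers; the step between them is a 5.2-fold lower number from compound 1 to compound 2 (0.71 log units; beyond the scatter). Compound 3 `COc1cc(-c2nnc(SCC(=O)NCc3ccc(Cl)cc3)n2N)cc(OC)c1OC` is not yet measured. It differs from compound 2 in one place: (4-chlorobenzyl)amino in place of 4-fluorophenyl on a carbonyl carbon. Going by the values given here, the only measured step alters a different part of the molecule, so it offers no clear guide to direction here. Compound 3 is therefore expected to give an estimated 5000 nM, within a range from 1500 nM to 20000 nM. That expectation amounts to a step of a 1.5-fold higher number from compound 2 to compound 3 (0.19 log units; within the scatter).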

Compound 3, half-maximal inhibitory concentration: > 100000 nM
Compound 3 was reported as a limit; the forecaster's own chance of this, stated with the estimate: 10%; middle value at least 20-fold (1.30 log units) from the limit.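

In this assay compound 3 gives only a limit of the assay, > 100000 nM, not a number. Putting (4-chlorobenzyl)amino on the carbonyl carbon in place of the aromatic group gives an at least 30-fold higher number from compound 2 to compound 3 (1.49 log units; beyond the scatter) and an at least 5.9-fold higher number from compound 1 to compound 3 (0.77 log units; beyond the scatter). The group on this carbonyl carbon therefore moves the read-out further than the earlier fluoro for trifluoromethyl swap did, and even compound 1 stays ahead of compound 3.

Which part of the new group matters stays open: the amide hydrogen, the benzyl chain or the chlorine. Phenylamino or unsubstituted benzylamino on the same carbonyl carbon would help separate these.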